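Phenyl to 4-fluorophenyl on the 2-nitrophenyl compound

The source may report more compounds than this note shows. Statements on the series, on what has been measured and on what is new or still open speak of the compounds shown alone.

In a functional assay on MCF7 cells (Homo sapiens) for cytotoxicity, read by MTT assay, with a stated time of 96 h (a lower number here means a stronger inhibitor, a higher number a weaker inhibitor), compound 2 (`COc1cc(C(=O)c2cn(-c3ccccc3)cc2-c2ccccc2[N+](=O)[O-])cc(OC)c1OC`) gives 49 nM and stands lowest of the three measured numbers. Compound 1 (`COc1cc(C(=O)c2cn(-c3ccccc3)cc2-c2cccc(Br)c2)cc(OC)c1OC`) gives 950 nM as its value, and compound 3 (`COc1ccc(Br)cc1-c1cn(-c2ccccc2)cc1C(=O)c1cc(OC)c(OC)c(OC)c1`) gives 2200 nM as its value. Compound 4 (`COc1cc(C(=O)c2cn(-c3ccc(F)cc3)cc2-c2ccccc2[N+](=O)[O-])cc(OC)c1OC`) has fluoro in place of hydrogen on an aromatic carbon, para to a large group. Going by the values given here, no measured step touches that phenyl. The steps of a 19-fold lower number from compound 1 to compound 2 (1.29 log units; beyond the scatter) and a 45-fold higher number from compound 2 to compound 3 (1.65 log units; beyond the scatter) are large but exchange a whole aromatic group. The nearest in kind is a 2.3-fold higher number from compound 1 to compound 3 (0.36 log units; beyond the scatter) and it is modest. Only a small change is therefore expected, a 1.2-fold higher number from compound 2 to compound 4 (0.09 log units; within the scatter) in this estimate, with no clear shift beyond the scatter. The estimated value for compound 4 is 60 nM with an expected range from 22 nM to 160 nM for this compound.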

Compound 4, half-maximal inhibitory concentration: 38 nM
Beside the measured number, compound 4's estimate is 1.6-fold (0.20 log units) above it, within the range that was stated.
By their numbers in this assay, from the lowest: compounds 4 and 2 (each within the scatter of the next); then compound 1; then compound 3.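

Fluoro in place of hydrogen, para to a large group, gives the first reading on this phenyl, which no earlier step touched. In this assay, the change gives a 1.3-fold lower number from compound 2 to compound 4 (0.11 log units; within the scatter), so compound 4 stays level with compound 2 and the low number of the 2-nitrophenyl compound holds with 4-fluorophenyl in place of phenyl. Nothing measured here bears on the reason for this result.

A single small atom is the only probe at this place, so an amine or a carboxylic acid there remains an open case. Going by these compounds, whether fluoro reads the same on the 3-bromophenyl compound 1 also stays open.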